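This account rests on a few compounds, and the source may have more. Where it says the series, first, only, none or still open, it means among the compounds named here.

Measured so far:
compound 1 `COc1cc(OC)c(/C=C/S(=O)(=O)Cc2ccc(OC)c([N+](=O)[O-])c2)c(OC)c1` — 2500 nM
compound 2 `COC(=O)C(Nc1cc(CS(=O)(=O)/C=C/c2c(OC)cc(OC)cc2OC)ccc1OC)c1ccc(Cl)cc1` — 200 nM
compound 3 `COC(=O)C(Nc1cc(CS(=O)(=O)/C=C/c2c(OC)cc(OC)cc2OC)ccc1OC)c1ccc(OC)cc1` — 150 nM

In a functional assay on K562 cells (Homo sapiens) for cytotoxicity, read by trypan blue exclusion, with a stated time of 96 h (on this read-out higher numbers stand for weaker inhibition and lower numbers for stronger inhibition), compound 2 gives 200 nM, the second highest of the three numbers. Its nearest neighbour is compound 3, which gives 150 nM, a value within the scatter of compound 2; compound 1 gives 2500 nM, a much higher number. Among the compounds with values here, the only measured single change, a 1.3-fold lower number from compound 2 to compound 3 (0.12 log units; within the scatter), shows that swapping one group on the outer aromatic ring left the number essentially unchanged.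

Compound 4 `COc1cc(OC)c(/C=C/S(=O)(=O)Cc2ccc(OC)c(NC(C(=O)O)c3ccc(Br)cc3)c2)c(OC)c1` differs from compound 2 in (4-bromophenyl)(carboxy)methyl in place of (4-chlorophenyl)(methoxycarbonyl)methyl on a nitrogen on an aromatic ring. Two things change at once: a bromine stands where a chlorine stood, and a carboxy group stands where a methoxycarbonyl group stood. The halogen exchange resembles the measured step in kind, which was within the scatter. Within the data shown here, no measured pair speaks to the carboxy for methoxycarbonyl exchange, so its effect is unknown and the uncertainty is wide. Compound 4 is therefore expected to give about 400 nM, with a range from 100 nM to 2000 nM, which would amount to an expected 2.0-fold higher number from compound 2 to compound 4 (0.30 log units; within the scatter).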

Compound 4, half-maximal inhibitory concentration: 200 nM
Beside the measured number, compound 4's estimate is 2.0-fold (0.30 log units) above it, and the stated range covers the measured number.
By their numbers in this assay, from the lowest: compounds 3, 2 and 4 (each within the scatter of the next); then compound 1.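

In this assay the combined exchange gives no change at the digits printed from compound 2 to compound 4 (within the scatter), so on this nitrogen a carboxy group with a 4-bromophenyl can stand where a methoxycarbonyl group with a 4-chlorophenyl stood, and the number stays within the scatter. The second step, a 13-fold lower number from compound 1 to compound 4 (1.10 log units; beyond the scatter), places ((4-bromophenyl)(carboxy)methyl)amino where nitro stood on the aromatic carbon, so a carboxy-bearing group at this place also lies far below the nitro compound. Nothing available explains either step.

On these data alone, the bromine and the carboxy group changed together, so whether each alone leaves the number unchanged or their effects offset each other stays open. Also open, as far as these compounds go, is how a primary amide or a tetrazole would read in place of the carboxy group.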